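Piperazine-linked benzimidazole thioethers: two measured, one expected

The source may hold more compounds than are shown below. What is called first, only, known or untested is meant among the compounds shown, and "the series" means these compounds.

Compound 1, `Clc1cccc(N2CCN(CCCSc3nc4ccccc4[nH]3)CC2)c1`, gives 54600 nM in a functional assay on MCF7 cells (Homo sapiens) for cytotoxicity, read by MTT assay, with a stated time of 24 h; on this read-out higher numbers stand for weaker inhibition and lower numbers for stronger inhibition.
Compound 2, `CCOc1ccccc1N1CCN(CCCSc2nc3cc(Cl)ccc3[nH]2)CC1`, gives 27700 nM in this assay.

The two numbers sit within the scatter of each other, so neither compound 1 nor compound 2 can be called the more active in this assay; both show only weak inhibition of these cells. Compound 3, `Clc1cccc(N2CCN(CCCSc3nc4cc(Cl)ccc4[nH]3)CC2)c1`, remains to be measured. It differs from compound 2 in one place: 3-chlorophenyl in place of 2-ethoxyphenyl on an amine nitrogen in a ring. Compound 3 carries the same 3-chlorophenyl group as compound 1, and compound 1 has a number that does not stand apart from compound 2 in this assay, so the change is expected to move the number little, if at all, beyond the scatter. Compound 3 is therefore estimated at 40000 nM in this assay, with a range from 15000 nM to 100000 nM. The estimated step of a 1.4-fold higher number from compound 2 to compound 3 (0.16 log units; within the scatter) is expected to lie within the scatter.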

Compound 3, half-maximal inhibitory concentration: 61400 nM
The estimate for compound 3 lay 1.5-fold (0.19 log units) below the measured number; the measured number falls inside the stated range.
By their numbers in this assay, from the lowest: compounds 2, 1 and 3 (each within the scatter of the next, the first and the last beyond it).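

On the amine nitrogen in a ring, 3-chlorophenyl in place of 2-ethoxyphenyl gives a 2.2-fold higher number from compound 2 to compound 3 (0.35 log units; beyond the scatter) in this assay, a modest step beyond the scatter that leaves compound 2 the stronger inhibitor of this pair. Chloro in place of hydrogen on an aromatic carbon of the core gives a 1.1-fold higher number from compound 1 to compound 3 (0.05 log units; within the scatter) and stays within the scatter, so in this pair the added chloro cannot be told from hydrogen. No supporting measurement explains either step.

The compounds shown leave open whether the 2-ethoxyphenyl result holds on the core without chloro, since only one aryl swap can be read here. They also leave open how an amine or a carboxylic acid on that aromatic ring, or a longer chain in the linker, would register in this assay as a number.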